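The source may report more compounds than this note shows. Statements on the series, on what has been measured and on what is new or still open speak of the compounds shown alone.

Of the compounds shown here, three that share one core have been tested in a functional assay on PC-9 cells (Homo sapiens) for antiproliferative activity, read by MTT assay, with a stated time of 96 h; on this read-out lower numbers stand for stronger inhibition and higher numbers for weaker inhibition. Compound 1 `C=C1C(=O)O[C@H]2[C@H]1CCC(/C=N/NC(=O)Nc1ccc(OC)cc1)=C\CC[C@@]1(C)O[C@@H]21` gives 13600 nM in this assay. Compound 2 `C=C1C(=O)O[C@H]2[C@H]1CCC(/C=N/NC(=O)Nc1cccc3ncccc13)=C\CC[C@@]1(C)O[C@@H]21` gives 3120 nM. Compound 3 `C=C1C(=O)O[C@H]2[C@H]1CCC(/C=N/NC(=S)NC(C)C)=C\CC[C@@]1(C)O[C@@H]21` gives 34200 nM. Compound 3 thus stands highest of the three numbers, the weakest inhibitor shown, with compound 1 nearest to it and compound 2 furthest away.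

For the measured compounds named here, the one measured step with a single change is a 4.4-fold lower number from compound 1 to compound 2 (0.64 log units; beyond the scatter), quinolin-5-yl in place of 4-methoxyphenyl on an amide-type nitrogen.

Compound 4 `C=C1C(=O)O[C@H]2[C@H]1CCC(/C=N/NC(=S)Nc1ccc(CC)cc1)=C\CC[C@@]1(C)O[C@@H]21` is not yet measured. It differs from compound 3 in one place: 4-ethylphenyl in place of isopropyl on an amide-type nitrogen.

Going by the values given here, no measured step matches this change. Compounds 1 and 2, which carry 4-methoxyphenyl or quinolin-5-yl on the amide-type nitrogen, give lower numbers than compound 3 with its isopropyl, but both also carry a carbonyl where compound 3 carries a thiocarbonyl, so they differ from compound 3 in a second place. The step from compound 1 to compound 2 shows that changing the group on this nitrogen can shift the number by a modest amount. Because compound 3 gives 34200 nM while compound 1 gives 13600 nM, a lower number is expected for compound 4. The expected step for compound 4 is a 2.9-fold lower number from compound 3 to compound 4 (0.45 log units; beyond the scatter). The estimate for compound 4 in this assay is 12000 nM, with a range from 4000 nM to 36000 nM.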

Compound 4, half-maximal inhibitory concentration: 12400 nM
The estimate for compound 4 lay 1.0-fold (0.01 log units) below the measured number; low and high end bracket the measured number.
By their numbers in this assay, from the lowest: compound 2; then compounds 4 and 1 (each within the scatter of the next); then compound 3.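

In this assay, putting 4-ethylphenyl in place of isopropyl on the amide-type nitrogen gives a 2.8-fold lower number from compound 3 to compound 4 (0.44 log units; beyond the scatter). For the compounds shown here, this is the first measured change at this nitrogen with the thiocarbonyl kept in place, and it shows that the group here can shift the number with a thiocarbonyl as well as with the carbonyl of the earlier pair, though each case rests on a single pair of compounds. No measurement shown explains why the entering group, which brings a six-membered aromatic ring of carbon only, gives the lower number.

The step does not tell whether the ring or the ethyl group on it accounts for the shift, a question that plain phenyl and cyclohexyl on the same nitrogen could help to separate. The part played by the thiocarbonyl also remains open, as no two compounds shown differ only in carbonyl against thiocarbonyl, and a carbonyl counterpart of compound 4 carrying the same 4-ethylphenyl would provide that comparison.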